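Agonist series at the chemokine receptor: three compounds at the limit

This account rests on a few compounds, and the source may have more. Where it says the series, first, only, none or still open, it means among the compounds named here.

Measured so far:
compound 1 `C(=C/CN(C[C@H]1Cc2ccccc2CN1)[C@H]1CCCc2cccnc21)\CNC1CCOCC1` — > 30000 nM
compound 2 `CC1(C)CCC(NC/C=C/CN(C[C@H]2Cc3ccccc3CN2)[C@H]2CCCc3cccnc32)CC1` — > 30000 nM
compound 3 `CC(C)(CCN(C[C@H]1Cc2ccccc2CN1)[C@H]1CCCc2cccnc21)CNC1CCOCC1` — > 30000 nM

In a functional assay on cells for agonist activity at C-X-C chemokine receptor type 4 (Homo sapiens), read by fluorescence and calcium flux, with a stated time of 90 s (on this read-out higher numbers stand for an effect only at larger amounts of compound and lower numbers for an effect already at smaller amounts), compound 1 gives only a limit, > 30000 nM. Compound 2 likewise gives only a limit in this assay, > 30000 nM. Compound 3 too sits at a limit, > 30000 nM. The change from compound 1 to compound 2 is 4,4-dimethylcyclohexyl in place of oxan-4-yl on an amine nitrogen; the step it made in this assay is a step that the two limits leave unreadable from compound 1 to compound 2, so its size is not readable, and the reason lies in the limit of > 30000 nM in this assay, at which 3 of the 3 values shown sit. The difference between the core of compound 1 and the core of compound 3 is not broken down here.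

Compound 4 `CC1(C)CCC(NCC(C)(C)CCN(C[C@H]2Cc3ccccc3CN2)[C@H]2CCCc3cccnc32)CC1` is not yet measured. It differs from compound 3 by 4,4-dimethylcyclohexyl in place of oxan-4-yl on an amine nitrogen, the same change as from compound 1 to compound 2, at a place described in the same words. Since compound 3 gives only a limit, > 30000 nM, and the earlier step that the two limits leave unreadable from compound 1 to compound 2 is unreadable, compound 4 is expected to give roughly 30000 nM, most likely again a limit, with a range from 8000 nM to 100000 nM. The expected step from compound 3 to compound 4 is a number no higher from compound 3 to compound 4 (the limit leaves the size open).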

Compound 4, half-maximal effective concentration: > 30000 nM
Compound 4 was reported as a limit (the forecaster's own chance of this, stated with the estimate: 85%); the middle value lies on the limit itself.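

In this assay compound 4 gives > 30000 nM, a limit and not a number. Compound 3 also sits at a limit, so no step can be read between compound 3 and compound 4: the limit of > 30000 nM in this assay, at which 4 of the 4 values shown sit.

The compounds shown leave open whether 4,4-dimethylcyclohexyl in place of oxan-4-yl changes anything in this assay, and at what concentration any of the four compounds would give an effect.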